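The source may report more compounds than this note shows. Statements on the series, on what has been measured and on what is new or still open speak of the compounds shown alone.

Series notes, step from compound 2 to compound 4.

Compound 2 `Cn1ncc(Cl)c1-c1cc(C(=O)N[C@@H]2CN[C@H](CCn3cncn3)C[C@H]2c2ccc(Cl)c(Cl)c2)oc1Cl` gives 60 nM in a functional assay on LNCaP cells (Homo sapiens) for antiproliferative activity (on this read-out higher numbers stand for weaker inhibition and lower numbers for stronger inhibition), the low end of the three numbers in hand. Compound 1 `Cn1ncc(Cl)c1-c1cc(C(=O)N[C@@H]2CN[C@H](CC(O)CO)C[C@H]2c2ccc(F)c(F)c2)oc1Cl` sits within the scatter of it at 100 nM, so no order between compound 1 and compound 2 can be read. Compound 3 `Cn1ncc(Cl)c1-c1cc(C(=O)N[C@@H]2CN[C@H](CC(=O)NCC(O)CO)C[C@H]2c2ccc(Cl)c(Cl)c2)oc1Cl` gives 660 nM; its gap to compound 2 is taken up below.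

Compound 4 `Cn1ncc(Cl)c1-c1cc(C(=O)N[C@@H]2CN[C@H](CC(=O)NCCO)C[C@H]2c2ccc(Cl)c(Cl)c2)oc1Cl` differs from compound 2 by (2-hydroxyethyl)carbamoyl in place of (1H-1,2,4-triazol-1-yl)methyl on a saturated chain carbon bound to a saturated ring carbon. Among the compounds with values here, the one measured step that bears on this is an 11-fold higher number from compound 2 to compound 3 (1.04 log units; beyond the scatter), where the same triazolylmethyl gave way to a carbamoyl chain carrying a diol. Compound 4 carries the shorter (2-hydroxyethyl)carbamoyl chain at the same place, so the step is expected in the same direction, a weakening, and of comparable though possibly somewhat smaller size: a 6.7-fold higher number from compound 2 to compound 4 (0.82 log units; beyond the scatter). Compound 4 is therefore expected to give about 400 nM in this assay, with a range from 150 nM to 1200 nM; only compound 3 anchors this expectation.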

Compound 4, half-maximal inhibitory concentration: 40 nM
Compound 4: the middle estimate sits 10-fold (1.00 log units) above what was measured; measured number below the stated range.
By their numbers in this assay, from the lowest: compounds 4, 2 and 1 (each within the scatter of the next, the first and the last beyond it); then compound 3.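

In this assay the carbamoyl link as such carries no penalty at this place, on a saturated chain carbon bound to a saturated ring carbon: (2-hydroxyethyl)carbamoyl in place of (1H-1,2,4-triazol-1-yl)methyl gives a step within the scatter (a 1.5-fold lower number from compound 2 to compound 4 (0.18 log units; within the scatter)), so the ring-free chain serves as well as the triazole-bearing one. The large gap seen with compound 3 therefore follows the hydroxymethyl on that chain, not the carbamoyl group, as hydrogen in place of hydroxymethyl shows (a 17-fold lower number from compound 3 to compound 4 (1.22 log units; beyond the scatter)). No measurement shown here accounts for that gap.

Going by these compounds, it remains open whether the gap belongs to the diol alone, which a primary amine, a carboxylic acid or a methoxy group at the end of the chain of compound 4 would test. On these data alone, a longer chain between the carbamoyl group and the hydroxyl is equally open.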